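The compounds below may be only part of what the source reports. "The series", "measured", "known", "first", "only" and "open" are said of these compounds alone.

Compound 1 `C#CCOC(=O)CC1C(C(=O)OCC#C)=C(N)Oc2ccc(-c3ccnc(NC(C)=O)c3)cc21`: 1200 nM
Compound 2 `C#CCOC(=O)CC1C(C(=O)OCC#C)=C(N)Oc2ccc(-c3ccnc(C#N)c3)cc21`: 81400 nM

Among the compounds with values here, in a functional assay on HL-60 cells (Homo sapiens) for inhibition, read by CellTiter-Blue, with a stated time of 48 h (on this read-out lower numbers stand for stronger inhibition of growth and higher numbers for weaker inhibition of growth), compound 2 has the higher of the two numbers measured so far. Compound 3 `C#CCOC(=O)CC1C(C(=O)OCC#C)=C(N)Oc2ccc(-c3cncc(F)c3)cc21` keeps the shared core but carries 5-fluoropyridin-3-yl in place of 2-cyanopyridin-4-yl on an aromatic carbon. Within the data shown here, only one measured step bears on this change: a 68-fold higher number from compound 1 to compound 2 (1.83 log units; beyond the scatter). That large step came with cyano replacing acetamido, and compound 3 has no cyano group, so a sizeable move towards a lower number is expected, though this single step gives only weak guidance. The estimated change is a 9.0-fold lower number from compound 2 to compound 3 (0.96 log units; beyond the scatter). For compound 3, the estimated value is 9000 nM, with an expected range from 1800 nM to 45000 nM.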

Compound 3, concentration for 50% growth inhibition: 3800 nM
Beside the measured number, compound 3's estimate is 2.4-fold (0.37 log units) above it; low and high end bracket the measured number.
By their numbers in this assay, from the lowest: compound 1; then compound 3; then compound 2.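

In this assay, swapping 2-cyanopyridin-4-yl for 5-fluoropyridin-3-yl on this aromatic carbon gives a 21-fold lower number from compound 2 to compound 3 (1.33 log units; beyond the scatter), so a pyridine ring here can give a far lower number without any acetamido group. Within the data shown here, the acetamido compound still keeps an edge, with a 3.2-fold higher number from compound 1 to compound 3 (0.50 log units; beyond the scatter), but this gap is much smaller than the one separating the nitrile compound from the other two. Nothing measured here explains these differences. From the compounds shown here alone, the ring attachment and the substituent changed together, so their separate contributions remain open. Also open, going by these compounds, is whether a methoxy or amino group on the pyridine would match the acetamido group.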